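Aryl replacement on the shared core: binding notes

A few compounds are considered here, and "the series" means these few. Any claim that something is new, unique, unknown or untested is made for them only; others in the source may bear on it.

Measured compounds:
compound 1 `Cn1c(-c2cccc(Cl)c2)nc2c(NC3CCCC3)ncnc21` — 6.5 nM
compound 2 `CCCn1c(-c2ccccc2)nc2c(NC3CCCCC3)ncnc21` — 27 nM

In an assay on CHO cells for displacement of a labelled ligand from adenosine receptor A1 (Homo sapiens), read by scintillation counting, with a stated time of 3 h (on this read-out higher numbers stand for weaker inhibition and lower numbers for stronger inhibition), compound 1 gives 6.5 nM, the lowest of the two numbers available. Compound 2 gives 27 nM in this assay, a higher number, and the gap between the two lies beyond the scatter. Within the data shown here, compound 1 and compound 2 differ in more than one place, so no single step can be read from that pair, and no step between measured compounds is available at all.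

Compound 3 `Cc1ccccc1-c1nc2c(NC3CCCC3)ncnc2n1C` has not yet been measured in this assay. It differs from compound 1 by 2-methylphenyl in place of 3-chlorophenyl on an aromatic carbon. Nothing measured here bears on this exchange directly, so the expectation rests on compound 1 alone. A modest step toward a higher number is expected, of a size that may stay within the scatter, as a 2.3-fold higher number from compound 1 to compound 3 (0.36 log units; beyond the scatter). Compound 3 is therefore estimated at 15 nM in this assay, with a range from 4 nM to 60 nM.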

Compound 3, inhibition constant: 55 nM
For compound 3 the middle estimate is 3.7-fold (0.56 log units) below the measured one, and the stated range covers the measured number.
By their numbers in this assay, from the lowest: compound 1; then compound 2; then compound 3.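

In this assay, among these compounds, 2-methylphenyl in place of 3-chlorophenyl on an aromatic carbon gives an 8.5-fold higher number from compound 1 to compound 3 (0.93 log units; beyond the scatter) and provides the first single-place step. This position, between two ring nitrogen atoms and next to the ring atom that bears a methyl group, therefore does not treat these two aryl groups alike, even though both are six-membered aromatic rings of carbon only, with the same number of heavy atoms and no hydrogen-bond donors or acceptors. No measurement on hand accounts for the size of this step.

The exchange alters both the substituent and its place on the phenyl ring, so the step cannot assign the change to chlorine versus methyl or to one ring position versus the other; 3-methylphenyl and 2-chlorophenyl on the core of compound 3 would separate those two changes. Steps involving compound 2 cannot be read, and the response of this position to a ring bearing an amine or a carboxylic acid also remains open.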